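The compounds below may be only part of what the source reports. "The series", "measured", "known", "first", "only" and "open" are said of these compounds alone.

The three compounds measured so far were all tested in an assay on isolated protein with Bile acid receptor (Homo sapiens) as the target; on this read-out higher numbers stand for an effect only at larger amounts of compound and lower numbers for an effect already at smaller amounts:

compound 1, `COC(=O)/C=C/c1cccc(N(Cc2ccc(/C=C/c3cc(C(F)(F)F)cc(C(F)(F)F)c3)cc2)C(=O)C(C)C)c1`, gives 1950 nM
compound 2, `COC(=O)/C=C/c1cccc(N(Cc2ccc(-c3cccc(C)c3)cc2)C(=O)C2CCCCC2)c1`, gives 109 nM
compound 3, `COC(=O)/C=C/c1cccc(N(Cc2ccc(-c3cccc(C)c3)cc2)C(=O)C(C)C)c1`, gives 163 nM

Compound 2 stands at the lowest number of the three. Its nearest neighbour is compound 3, and the step of a 1.5-fold higher number from compound 2 to compound 3 (0.17 log units; within the scatter) lies within the scatter, so these two cannot be told apart. Going by the values given here, compound 1 stands furthest from compound 2, at a number well beyond the scatter; it differs from compound 2 in more than one place, so no single step is drawn from that pair.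

The next compound, compound 4, is `COC(=O)/C=C/c1cccc(N(Cc2ccc(/C=C/C(=O)OCc3ccccc3)cc2)C(=O)C2CCCCC2)c1`. Compared with compound 2 the change is 2-(benzyloxycarbonyl)ethenyl in place of 3-methylphenyl on an aromatic carbon. Among the compounds with values here, no measured step touches this position: the only step recorded concerns the group on the carbonyl carbon and was within the scatter. Within the data shown here, the only loose hint is compound 1, whose much higher number came with a large, extended group at the same end of the molecule, together with other changes. On that basis compound 4 is expected to give a somewhat higher number than compound 2, a step of a 3.7-fold higher number from compound 2 to compound 4 (0.56 log units; beyond the scatter), with wide uncertainty. The estimate for compound 4 in this assay is 400 nM, in a range from 100 nM to 1600 nM.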

Compound 4, half-maximal effective concentration: > 1000 nM
Compound 4: only a limit was reported; the forecaster's own chance of this, stated with the estimate: 5%; middle value at least 2.5-fold (0.39 log units) from the limit.
By their numbers in this assay, from the lowest: compounds 2 and 3 (each within the scatter of the next); then compound 1.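

In this assay, compound 4 gives > 1000 nM, which is a limit of the assay and not a number. The group on this aromatic carbon, para to a large group, clearly matters here: 2-(benzyloxycarbonyl)ethenyl in place of 3-methylphenyl gives an at least 9.1-fold higher number from compound 2 to compound 4 (0.96 log units; beyond the scatter), whereas the change on the carbonyl carbon gave a 1.5-fold higher number from compound 2 to compound 3 (0.17 log units; within the scatter). The full size of the step stays unknown because the value of compound 4 is a limit: the limit of > 1000 nM in this assay, at which 1 of the 4 values shown sits.

The swap brings in more heavy atoms, two double bonds outside aromatic rings and two hydrogen-bond acceptors all at once, and the compounds shown cannot tell which of these changes counts, nor whether the distant benzyl ester matters more than the ethenyl link. Also open, from the compounds shown here alone, is how this position would read with a free carboxylic acid at the end of the ethenyl link, a small methyl ester in place of the benzyl ester, or an amine on the ring that replaces 3-methylphenyl's methyl group.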